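The compounds below may be only part of what the source reports. "The series", "measured", "known", "first", "only" and "open" are said of these compounds alone.

Measured compounds:
Compound 1, `COc1cc2c(cc1OC)C(=O)C(CC1CCN(C(=S)Nc3ccccc3C)CC1)C2`: 300 mg/kg
Compound 2, `COc1cc2c(cc1OC)C(=O)C(CC1CCN(C(=S)Nc3ccc(C)cc3)CC1)C2`: 100 mg/kg
Compound 3, `COc1cc2c(cc1OC)C(=O)C(CC1CCN(C(=S)Nc3cccc([N+](=O)[O-])c3)CC1)C2`: "not determined" (no result reported)

The three compounds share a common core and differ only in the aryl group attached to the thiourea nitrogen. In a functional assay on the whole organism (strain Swiss albino) with Mus musculus as the target, with a stated time of 0.5 h (a lower number here means that less compound is needed, a higher number that more compound is needed for the effect), compound 1 gives 300 mg/kg, while compound 2 gives 100 mg/kg. For compound 3 no result was reported in this assay, so it has no number to stand on; it is only defined by its structure.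

Compound 4, `COc1cc2c(cc1OC)C(=O)C(CC1CCN(C(=S)Nc3ccccc3Cl)CC1)C2`, is the next step from compound 3. The change is 2-chlorophenyl in place of 3-nitrophenyl on an amide-type nitrogen.

Going by the values given here, the only measured step available is a 3.0-fold lower number from compound 1 to compound 2 (0.48 log units; beyond the scatter), and it concerns a different pair of substituents, a shift of a methyl group around the phenyl ring. It bears on compound 4 only in a loose way: compound 4, like compound 1, carries its single substituent as a 2-substituted phenyl, and compound 1 is the higher-dose member of the measured pair. Among the compounds with values here, no step links compound 3 to any measured compound, so nothing about the nitro group can be read from the numbers.

On that thin footing, compound 4 is expected to land in this assay near the level of compound 1, at an estimated 200 mg/kg, with a range from 100 mg/kg to 300 mg/kg.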

Compound 4, minimum effective dose: 300 mg/kg
The estimate for compound 4 lay 1.5-fold (0.18 log units) below the measured number; low and high end bracket the measured number.
By their numbers in this assay, from the lowest: compound 2; then compounds 1 and 4 (each within the scatter of the next).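

In this assay, chloro in place of methyl on an aromatic carbon brings no change at the digits printed from compound 1 to compound 4 (within the scatter), so 2-chlorophenyl and 2-methylphenyl on this amide-type nitrogen cannot be told apart by their numbers. The comparison with the other methyl compound gives a 3.0-fold higher number from compound 2 to compound 4 (0.48 log units; beyond the scatter), which means that compound 2, with its 4-methylphenyl, now stands apart from both the 2-methylphenyl and the 2-chlorophenyl compounds, and among these three compounds the difference follows the substituent's place on the ring rather than the choice of chloro or methyl. No evidence is available that speaks to the reason for these numbers.

As far as these compounds go, the step from compound 3 cannot be read, so the standing of 3-nitrophenyl relative to 2-chlorophenyl remains unknown. From the compounds shown here alone, it also remains open whether the lower number of compound 2 belongs to 4-methylphenyl alone or would carry over to other groups on this nitrogen, such as a plain phenyl, a methoxyphenyl or an aminophenyl.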